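Adding a Methyl Group to Compound 2

The source may report more compounds than this note shows. Statements on the series, on what has been measured and on what is new or still open speak of the compounds shown alone.

Measured compounds:
compound 1, `Cc1ccc(-c2c(S(=O)(=O)c3ccccc3)cnc3c(Br)c(-c4ccccc4)nn23)cc1`, 54.8%
compound 2, `Cc1ccc(-c2c(S(=O)(=O)c3ccccc3)cnc3cc(-c4ccccc4)nn23)cc1`, 36.4%

Of the compounds shown here, two have been measured in a functional assay on the whole organism for inhibition, with Mus musculus as the target, with a stated time of 3 h, at a dose of 50 mg/kg by the oral route; a higher number here means more inhibition at the dose given (going by the name of the read-out), a lower number less inhibition. Compound 1 gives 54.8%, and compound 2 gives 36.4%, the lower of the two numbers. Going by the values given here, the one known step, a number 18.4 percentage points lower from compound 1 to compound 2 (beyond the scatter), arises from a hydrogen in place of bromo on an aromatic carbon.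

Compound 3, `Cc1ccc(-c2cc3ncc(S(=O)(=O)c4ccccc4)c(-c4ccc(C)cc4)n3n2)cc1`, has not been measured. It differs from compound 2 by methyl in place of hydrogen on an aromatic carbon, sitting on an aromatic carbon of a six-membered aromatic ring of carbon only, para to a large group; cut one bond further out, the difference reads phenyl to 4-methylphenyl.

Among the compounds with values here, no measured step concerns a methyl in place of hydrogen, so the step between compound 1 and compound 2 does not bear directly on this change. Compound 3 is therefore expected to lie close to compound 2, with an expected step of a number 1.6 percentage points higher from compound 2 to compound 3 (within the scatter), within the scatter and in no set direction. Compound 3 is estimated at 38%, with a range from 18% to 58%.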

Compound 3, a percentage reported as inhibition, in the whole organism at one dose (the size of the read-out at that dose, not a potency): 31.2%
Compound 3: middle estimate off by 6.8 percentage points, on the high side; the range from low to high includes it.
By their numbers in this assay, from the lowest: compounds 3 and 2 (each within the scatter of the next); then compound 1.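

In this assay, the change from phenyl to 4-methylphenyl, on an aromatic carbon para to a large group, gives a number 5.2 percentage points lower from compound 2 to compound 3 (within the scatter), so compound 2 and compound 3 cannot be told apart at this dose. Going by these compounds alone, this is the first information on this ring, since the earlier pair spoke only to a different place on the molecule, where hydrogen in place of bromo gave a number 18.4 percentage points lower from compound 1 to compound 2 (beyond the scatter), a step printed as beyond the scatter. A single added methyl at this position therefore leaves the read-out within the usual scatter, whereas the bromo change does not, and nothing shown here explains this result.

On these data alone, whether a different group at this same position, such as an amine, a carboxylic acid or a longer chain, would move the inhibition beyond the scatter remains open, as one methyl says little about other groups there. It is also open whether the methyl would give a similar step in the presence of the bromo of compound 1, since the two changes are not seen together in any compound shown.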